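Pyrimidine cyanosugar nucleosides: step from compound 3 to compound 4

The compounds below may be only part of what the source reports. "The series", "measured", "known", "first", "only" and "open" are said of these compounds alone.

Measured so far in a functional assay on CCRF-CEM cells (Homo sapiens); a lower number here means a stronger inhibitor, a higher number a weaker inhibitor:
Compound 1 `N#C[C@]1(O)[C@H](O)[C@@H](CO)O[C@@H](n2ccc(O)nc2=O)[C@@H]1O`: > 500000 nM, a limit of the assay and not a number.
Compound 2 `Cc1cn([C@@H]2O[C@H](CO)[C@@H](O)[C@@](O)(C#N)[C@H]2O)c(=O)nc1O`: > 500000 nM, likewise a limit.
Compound 3 `N#C[C@H]1[C@@H](O)[C@H](n2cc(F)c(O)nc2=O)O[C@H](CO)[C@H]1O`: > 500000 nM, likewise a limit.

Compound 3 thus stands at the limit shared by every value in hand, (the limit of > 500000 nM in this assay, at which 3 of the 3 values shown sit). Among the compounds with values here, the only measured step, a step that the two limits leave unreadable from compound 1 to compound 2, cannot be read; both of its ends are limits. Compound 4 `Cc1cn([C@@H]2O[C@H](CO)[C@@H](O)[C@@H](C#N)[C@H]2O)c(=O)nc1O` differs from compound 3 by methyl in place of fluoro on an aromatic carbon. Within the data shown here, no readable step bears on this change, and nothing among the measured values points to a gain beyond the scatter. The expected step is a number no higher from compound 3 to compound 4 (the limit leaves the size open). Compound 4 is estimated at 500000 nM, with a range from 100000 nM to 2000000 nM, in this assay, most likely reported again only as a limit.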

Compound 4, half-maximal inhibitory concentration: > 750000 nM
Compound 4: no number, only a limit; the forecaster's own chance of this, stated with the estimate: 85%; middle value at least 1.5-fold (0.17 log units) away from the limit.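

Compound 3 and compound 4 are both limits of the assay and not numbers in this assay, so the step between them cannot be read. The compounds shown leave open the size and direction of methyl in place of fluoro on an aromatic carbon on the shared core.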